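The compounds below may be only part of what the source reports. "The series", "measured", "known", "first", "only" and "open" are said of these compounds alone.

Measured compounds in an ADME assay on L02 cells (Homo sapiens) for cytotoxicity, read by MTT assay, with a stated time of 24 h; a lower number here means that less compound is tolerated, a higher number that more compound is tolerated:
compound 1 `O=c1[nH]cc(S(=O)(=O)Nc2ccccc2-c2cn(-c3ccccc3)nn2)c(=O)[nH]1`: 10600 nM
compound 2 `Cc1cccc(-n2cc(-c3ccccc3NS(=O)(=O)c3c[nH]c(=O)[nH]c3=O)nn2)c1`: 21900 nM
compound 3 `O=c1[nH]cc(S(=O)(=O)Nc2ccccc2-c2cn(-c3ccc(F)cc3)nn2)c(=O)[nH]1`: "not toxic" (no number reported) (no number)

Compound 4 `O=c1[nH]cc(S(=O)(=O)Nc2ccccc2-c2cn(-c3ccccc3Cl)nn2)c(=O)[nH]1` is not yet measured.

Compound 3 stands outside the numbers shown: in this assay compound 3 is recorded only as "not toxic" (no number reported), with no concentration given, so it cannot be placed against compound 1 or compound 2 on a scale. For the measured compounds named here, compound 1 and compound 2 both give numbers of similar size in this assay, and the one measured step, a 2.1-fold higher number from compound 1 to compound 2 (0.32 log units; beyond the scatter), is modest.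

The change from compound 3 to compound 4 is 2-chlorophenyl in place of 4-fluorophenyl on an aromatic nitrogen. Going by the values given here, no measured step concerns the group on that aromatic nitrogen changing between two substituted phenyls; the only step known, a 2.1-fold higher number from compound 1 to compound 2 (0.32 log units; beyond the scatter), is on a different position and of another kind, so it bears only loosely here. Given that all three measured compounds sit in the same broad region or are untoxic, no step beyond the scatter is expected in this assay for compound 4 relative to the series. The estimate for compound 4 in this assay is 20000 nM, within 8000 nM to 60000 nM, with a fair chance that only "not toxic" is reported.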

Compound 4, half-maximal cytotoxic concentration: 22800 nM
The estimate for compound 4 lay 1.1-fold (0.06 log units) below the measured number, within the range that was stated.
By their numbers in this assay, from the lowest: compound 1; then compounds 2 and 4 (each within the scatter of the next).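

In this assay there is a 2.2-fold higher number from compound 1 to compound 4 (0.33 log units; beyond the scatter) as a modest step, so a second substituted phenyl on the aromatic nitrogen now carries a number. With 2-chlorophenyl in place of 3-methylphenyl there is a 1.0-fold higher number from compound 2 to compound 4 (0.02 log units; within the scatter) and the two substituted phenyls are not told apart, while both stand beyond the scatter from compound 1; steps to compound 3, recorded only as "not toxic", cannot be read. No measurement shown offers a reason for these steps.

Still open, from the compounds shown here alone, is how a phenyl bearing a carboxylic acid or an amine on that aromatic nitrogen would read in this assay and whether it would stay in the same range. A saturated alkyl chain in place of the phenyl at this position is equally untested by the compounds shown.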